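The source may report more compounds than this note shows. Statements on the series, on what has been measured and on what is new or still open speak of the compounds shown alone.

Compound 1, `CCOC(=O)C1=Cc2ccccc2OC1(OCc1cn(-c2ccc(F)cc2)nn1)C(F)(F)F`, is the only one of the three measured compounds for which a functional assay on MCF7 cells (Homo sapiens) for inhibition, read by MTT assay, with a stated time of 24 h (a higher number here means a weaker inhibitor, a lower number a stronger inhibitor), returns a number: in it compound 1 gives 9100 nM. Compound 2, `CCOC(=O)C1=Cc2ccccc2OC1(OCc1cn(CC(=O)Nc2ccc(C)cc2)nn1)C(F)(F)F`, reaches only a limit of this assay, and for compound 2 the result is > 150000 nM. Compound 3, `CCOC(=O)C1=Cc2ccccc2OC1(OCc1cn(-c2ccccc2)nn1)C(F)(F)F`, also stops at a limit, and for compound 3 the result is > 150000 nM. Among the measured compounds shown here, both of those results sit at the limit of > 150000 nM in this assay, at which 2 of the 3 values shown sit, so compound 1 stands alone as the single readable value.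

The measured steps are an at least 16-fold higher number from compound 1 to compound 2 (1.21 log units; beyond the scatter) and an at least 16-fold higher number from compound 1 to compound 3 (1.21 log units; beyond the scatter), while a step that the two limits leave unreadable from compound 2 to compound 3 cannot be read because both ends are limits.

Compound 4, `CCOC(=O)C1=Cc2ccccc2OC1(OCc1cn(-c2ccc(F)c([N+](=O)[O-])c2)nn1)C(F)(F)F`, differs from compound 1 by nitro in place of hydrogen on an aromatic carbon. For the measured compounds named here, the two steps that bear on this change both start from compound 1: the first replaces the whole group on the aromatic nitrogen, the second removes the fluoro. Neither adds a nitro, so they give only a rough guide; the fluoro whose loss gave an at least 16-fold higher number from compound 1 to compound 3 (1.21 log units; beyond the scatter) is kept in compound 4, so a moderate weakening rather than a collapse is expected. For compound 4 the estimate in this assay is 18000 nM, between 4000 nM and 150000 nM. The expected step is a 2.0-fold higher number from compound 1 to compound 4 (0.30 log units; within the scatter).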

Compound 4, half-maximal inhibitory concentration: 16200 nM
Compound 4: middle estimate off by 1.1-fold (0.05 log units), on the high side; measured number inside the range.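

Placing a nitro on this aromatic carbon, ortho to a fluoro group, leaves the activity of compound 1 essentially unchanged in this assay, with a 1.8-fold higher number from compound 1 to compound 4 (0.25 log units; within the scatter), so this position accepts a group of 3 heavy atoms without a loss that can be told from the scatter. The 4-fluoro-3-nitrophenyl group also sets compound 4 clearly apart from the two compounds without a readable value, with an at least 9.2-fold lower number from compound 3 to compound 4 (0.96 log units; beyond the scatter) and an at least 9.2-fold lower number from compound 2 to compound 4 (0.96 log units; beyond the scatter). Both of these steps start from a limit and not from a number, so each gives only a minimum size: the limit of > 150000 nM in this assay, at which 2 of the 4 values shown sit.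

The compounds shown leave open whether a nitro at this position would give a readable value on a phenyl ring that lacks the fluoro, as the step from compound 3 to compound 4 adds both groups at once. They also leave open how other groups would behave on the same aromatic carbon, for example an amine, a carboxylic acid or a longer chain such as propyl.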